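Mirror image of a bile acid receptor agonist

A few compounds are considered here, and "the series" means these few. Any claim that something is new, unique, unknown or untested is made for them only; others in the source may bear on it.

Measured compounds:
- compound 1, `O=C(O)c1cccc([C@H]2C[C@@H](c3ccc(OCc4c(-c5c(Cl)cccc5Cl)noc4C4CC4)cc3Cl)C2)c1`: 88%
- compound 2, `CCO[C@]1(c2ccc(OCc3c(-c4c(Cl)cccc4Cl)noc3C3CC3)cc2Cl)C[C@H](c2cccc(C(=O)O)c2)C1`: 89%

In an assay on HEK293 cells for agonist activity at Bile acid receptor (Homo sapiens) (on this read-out lower numbers stand for smaller maximal responses and higher numbers for larger maximal responses), compound 1 gives 88% and compound 2 gives 89%; the two values lie within the usual scatter of each other, so neither can be called the larger. Among the measured compounds shown here, the one step available, a number 1 percentage points higher from compound 1 to compound 2 (within the scatter), concerns an ethoxy in place of hydrogen on a saturated ring carbon, not a change of configuration, so it says nothing direct about compound 3, `O=C(O)c1cccc([C@H]2C[C@H](c3ccc(OCc4c(-c5c(Cl)cccc5Cl)noc4C4CC4)cc3Cl)C2)c1`. Compound 3 differs from compound 1 as follows: the two compounds have the same atoms and bonds and differ only in configuration as drawn: 2 of 2 stereo elements differ (all stereocentres are inverted: mirror images); a stereocentre at a saturated ring carbon is drawn s in compound 1 and r in compound 3; a stereocentre at a saturated ring carbon is drawn s in compound 1 and r in compound 3. For the measured compounds named here, no measured pair shows what inverting both stereocentres does here, so the expectation rests on the shared core alone. A mirror image may keep or lose response, and the estimate for compound 3 in this assay is therefore 70%, within 30% to 100%, a step of a number 18 percentage points lower from compound 1 to compound 3 (beyond the scatter) expected with low confidence.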

Compound 3, largest response reached (reported as efficacy), in percent of the reference or control that the assay uses: 89%
Compound 3: the middle estimate sits 19 percentage points below what was measured; low and high end bracket the measured number.
By their numbers in this assay, from the lowest: compounds 1, 2 and 3 (each within the scatter of the next).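

Inverting both stereocentres gives a number 1 percentage points higher from compound 1 to compound 3 (within the scatter) in this assay, so the mirror image reaches a maximal response that cannot be told apart from that of compound 1. The earlier step concerned only an ethoxy on a saturated ring carbon, whereas this one tests the spatial arrangement of the shared core itself. It can be read as an effect of configuration alone, because nothing else separates the pair: the fact that compounds 1 and 3 differ only in the configuration as drawn.

From the compounds shown here alone, this read-out gives the size of the largest response, so the concentration each mirror image needs to reach it remains open. Also open, going by these compounds, is whether configuration would stay just as silent with an amine on that saturated ring carbon, or with an amide in place of the carboxylic acid.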